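Swapping cyclopropylamino for pyrrolidin-1-yl on the shared core

The source may report more compounds than this note shows. Statements on the series, on what has been measured and on what is new or still open speak of the compounds shown alone.

In an ADME assay on BCBL1 cells (Homo sapiens) for cytotoxicity, with a stated time of 7 days (a lower number here means that less compound is tolerated, a higher number that more compound is tolerated), compound 1 `CCCSc1nc(N)nc2c1ncn2/C=C1/CC1(CO)CO` gives > 20000 nM, which is a limit and not a number. Compound 2 `Nc1nc(NCc2ccccc2)c2ncn(/C=C3/CC3(CO)CO)c2n1` gives 19900 nM, and compound 3 `Nc1nc(NC2CC2)c2ncn(/C=C3/CC3(CO)CO)c2n1` gives 71500 nM, the higher of the two actual numbers.

Compound 4 `Nc1nc(N2CCCC2)c2ncn(/C=C3/CC3(CO)CO)c2n1` has pyrrolidin-1-yl in place of the cyclopropylamino of compound 3, on an aromatic carbon: pyrrolidin-1-yl in place of cyclopropylamino on an aromatic carbon.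

The two steps that start from compound 1 have no readable size, since they rest on (the limit of > 20000 nM in this assay, at which 1 of the 3 values shown sits). That leaves one usable guide, a modest change beyond the scatter: a 3.6-fold higher number from compound 2 to compound 3 (0.56 log units; beyond the scatter). Within the data shown here, no measured compound carries pyrrolidin-1-yl, so the direction of the new step is uncertain. A slight lean downward is expected, as compound 3 at 71500 nM is already the highest number in this assay. The estimated change is small and not expected to exceed the scatter: a 1.6-fold lower number from compound 3 to compound 4 (0.20 log units; within the scatter). For compound 4 the expected value is 45000 nM, with an estimated range of 15000 nM to 110000 nM.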

Compound 4, half-maximal cytotoxic concentration: > 20000 nM
Compound 4: no number, only a limit; the forecaster's own chance of this, stated with the estimate: 35%; the middle value is on the limit's open side.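

In this assay compound 4 gives > 20000 nM, which is a limit and not a number. One direction can still be read against the benzylamino compound: a number no lower from compound 2 to compound 4 (the limit leaves the size open). So at this aromatic carbon of the shared core, pyrrolidin-1-yl, with 0 hydrogen-bond donors where the cyclopropylamino it replaces has 1, gives a number that does not fall under that of compound 2.

Going by these compounds, the steps from compound 3 and from compound 1 cannot be read: the limit of > 20000 nM in this assay, at which 2 of the 4 values shown sit. Whether compound 4 comes close to compound 3, at 71500 nM, stays open, as does what a six-membered piperidin-1-yl or an open-chain dimethylamino would give at the same carbon.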